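Moving a Pyrrolidine Link on a Weak Inhibitor

The compounds below may be only part of what the source reports. "The series", "measured", "known", "first", "only" and "open" are said of these compounds alone.

In a functional assay on MCF7 cells (Homo sapiens) for inhibition, read by fluorescence, with a stated time of 72 h (a higher number here means a weaker inhibitor, a lower number a stronger inhibitor), compound 1 `CC(C)n1cnc2c(NC(=N)N)nc(NCCCCCCO)nc21` gives 5200 nM. Compound 2 `CC(C)n1cnc2c(NC(=N)N)nc(OC[C@@H]3CCCN3)nc21` reads > 100000 nM, which is a limit of the assay and not a number. It therefore stands at the limit of > 100000 nM in this assay, at which 1 of the 2 values shown sits. For the measured compounds named here, the one measured step bearing on the change is large and beyond the scatter: an at least 19-fold higher number from compound 1 to compound 2 (1.28 log units; beyond the scatter). In compound 3 `CC(C)n1cnc2c(NC(=N)N)nc(N3CCC[C@H]3CO)nc21` the same atoms are joined differently: 2-(hydroxymethyl)pyrrolidin-1-yl in place of (pyrrolidin-2-yl)methoxy on an aromatic carbon. The entering group, like the (6-hydroxyhexyl)amino group of compound 1 at 5200 nM, is attached through nitrogen and carries a hydroxyl, though within a five-membered ring rather than a chain. A large step towards a lower number in this assay is therefore expected, recovering only part of the measured loss. The expected change is an at least 4.0-fold lower number from compound 2 to compound 3 (0.60 log units; beyond the scatter). For compound 3 the estimated value is 25000 nM, with an expected range of 6000 nM to 100000 nM.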

Compound 3, half-maximal inhibitory concentration: 6200 nM
For compound 3 the middle estimate is 4.0-fold (0.61 log units) above the measured one; measured number inside the range.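

At this position, between two ring nitrogen atoms, the same atoms read very differently in this assay depending on how they are joined: the change to the nitrogen-linked 2-(hydroxymethyl)pyrrolidin-1-yl group gives an at least 16-fold lower number from compound 2 to compound 3 (1.20 log units; beyond the scatter). The two nitrogen-linked groups carrying a hydroxyl, a chain in one and a five-membered ring in the other, cannot be told apart, with a 1.2-fold higher number from compound 1 to compound 3 (0.08 log units; within the scatter), so the ring in place of the chain shows no measurable effect here. The reading for compound 2 is a limit of the assay and not a number, so the first step is a bound: the limit of > 100000 nM in this assay, at which 1 of the 3 values shown sits.

The compounds shown leave open whether the hydroxyl matters at all, which a plain pyrrolidin-1-yl group would address. Also open, as far as these compounds go, is whether a (6-hydroxyhexyl)oxy chain, linked through oxygen, would read like compound 2.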